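Sulfonyl aryl substituent variation: from compound 3 to compound 4

A few compounds are considered here, and "the series" means these few. Any claim that something is new, unique, unknown or untested is made for them only; others in the source may bear on it.

Measured so far in an assay on Sf9 cells for inhibition of mitogen-activated protein kinase kinase kinase 20 (Homo sapiens), read by ADP-Glo, with a stated time of 30 min; a lower number here means a stronger inhibitor, a higher number a weaker inhibitor:
compound 1, `COc1n[nH]c2ncc(-c3cn(-c4c(F)ccc(NS(=O)(=O)c5cccc(Cl)c5)c4F)nn3)cc12`, gives 1.9 nM
compound 2, `COc1n[nH]c2ncc(-c3cn(-c4c(F)ccc(NC(=O)c5cccc(Cl)c5)c4F)nn3)cc12`, gives 54.3 nM
compound 3, `COc1n[nH]c2ncc(-c3cn(-c4c(F)ccc(NS(=O)(=O)c5cccc(C#N)c5)c4F)nn3)cc12`, gives 3.3 nM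

Compound 3 stands second highest of the three numbers. Its nearest neighbour is compound 1, the pair lying within the scatter (a 1.7-fold higher number from compound 1 to compound 3 (0.24 log units; within the scatter)); its furthest is compound 2 (a 16-fold lower number from compound 2 to compound 3 (1.22 log units; beyond the scatter)).

Compound 4, `COc1n[nH]c2ncc(-c3cn(-c4c(F)ccc(NS(=O)(=O)c5cccc(-c6ccccc6)c5)c4F)nn3)cc12`, is not yet measured. It differs from compound 3 in one place: phenyl in place of cyano on an aromatic carbon.

Of the measured steps, a 1.7-fold higher number from compound 1 to compound 3 (0.24 log units; within the scatter) bears most directly: it exchanges chloro for cyano on the same aromatic carbon meta to a large group, and the number stays within the scatter. The two large steps, a 29-fold higher number from compound 1 to compound 2 (1.46 log units; beyond the scatter) and a 16-fold lower number from compound 2 to compound 3 (1.22 log units; beyond the scatter), concern the sulfonyl against the carbonyl link on the nitrogen; compound 4 keeps the sulfonyl link of compound 3, so they do not bear on this change. Among the compounds with values here, no measured compound carries phenyl, or any group of that count of heavy atoms, at this carbon, so the data give no direct guide to a group of that size.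

The expectation for compound 4 is therefore a modest step, likely within or just beyond the scatter, toward a higher number: a 1.8-fold higher number from compound 3 to compound 4 (0.26 log units; within the scatter).

Compound 4 is estimated at 6 nM, with a range of 1.5 nM to 30 nM.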

Compound 4, half-maximal inhibitory concentration: 4 nM
Estimate against measurement, compound 4: 1.5-fold (0.18 log units) above; the measured number falls inside the stated range.
By their numbers in this assay, from the lowest: compounds 1, 3 and 4 (each within the scatter of the next, the first and the last beyond it); then compound 2.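

In this assay, phenyl in place of cyano on this aromatic carbon gives a 1.2-fold higher number from compound 3 to compound 4 (0.08 log units; within the scatter), so a group of 6 heavy atoms, with one six-membered aromatic ring of carbon only and 0 hydrogen-bond acceptors, is accommodated here without a change beyond the scatter from the 2 heavy atoms of cyano. Against chloro at the same carbon, the step is a 2.1-fold higher number from compound 1 to compound 4 (0.32 log units; beyond the scatter), the only step among the three groups at this carbon that lies beyond the scatter, and it remains much smaller than the exchange of sulfonyl for carbonyl on the nitrogen, a 29-fold higher number from compound 1 to compound 2 (1.46 log units; beyond the scatter). No measurement is available that accounts for this behaviour at the position.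

The compounds shown leave open whether this carbon also accepts an amine, a carboxylic acid, a longer alkyl chain or a phenyl ring carrying a further substituent. They also leave open whether phenyl would give a similar number at another carbon of this ring, or on the carbonyl-linked series represented by compound 2.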